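Methyl on the benzoyl ring: notes and an estimate

A few compounds are considered here, and "the series" means these few. Any claim that something is new, unique, unknown or untested is made for them only; others in the source may bear on it.

Measured so far in a functional assay on GLC82 cells (Homo sapiens) for cytotoxicity, read by MTT assay, with a stated time of 72 h; a lower number here means a stronger inhibitor, a higher number a weaker inhibitor:
compound 1 `O=C(NC(=S)NNc1ncnc2ccccc12)c1ccccc1` gives 8370 nM
compound 2 `COc1cc2ncnc(NNC(=S)NC(=O)c3ccccc3)c2cc1OC` gives 6550 nM
compound 3 `Cc1ccc(C(=O)NC(=S)NNc2ncnc3ccccc23)cc1` gives 11200 nM

The three numbers sit close together. From compound 1 to compound 3 the change is methyl in place of hydrogen on an aromatic carbon, and the step was a 1.3-fold higher number from compound 1 to compound 3 (0.13 log units; within the scatter). Compound 2 carries a different core from compound 1; the difference between the two cores is not broken down here. What the two values show is that compound 2 and compound 1 fall within the usual scatter of each other in this assay, as do compound 2 and compound 3.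

Compound 4 `COc1cc2ncnc(NNC(=S)NC(=O)c3ccccc3C)c2cc1OC` has not yet been measured. It is built from compound 2 by methyl in place of hydrogen on an aromatic carbon. Among the measured compounds shown here, this is the same kind of change as the one from compound 1 to compound 3, but not the same: there the methyl sits para to a large group, here it sits ortho to a large group. For the measured compounds named here, only one earlier instance of the change is at hand, and it was within the scatter.

Going by the values given here, compound 4 is expected to show a step of a 1.3-fold higher number from compound 2 to compound 4 (0.11 log units; within the scatter), resting on the one earlier step of a 1.3-fold higher number from compound 1 to compound 3 (0.13 log units; within the scatter) being small and on compound 2 giving 6550 nM. For compound 4 the estimate in this assay is 8500 nM, expected to fall between 3500 nM and 20000 nM.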

Compound 4, half-maximal inhibitory concentration: 21500 nM
Compound 4: the middle estimate sits 2.5-fold (0.40 log units) below what was measured, outside the stated range (above it).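

In this assay the methyl change gives a 3.3-fold higher number from compound 2 to compound 4 (0.52 log units; beyond the scatter), so on this core the 2-methylphenyl compound reads as weaker than its parent, a modest step that lies beyond the scatter. Set beside the earlier instance, the step on this core does not separate from the one on the other core: the same change on two cores in this assay, a 1.3-fold higher number (0.13 log units; within the scatter) from compound 1 to compound 3 and a 3.3-fold higher number (0.52 log units; beyond the scatter) from compound 2 to compound 4, 2.5-fold (0.39 log units) apart, within the scatter of two such steps The series therefore gives no ground to say that the change behaves differently on the two cores, nor does it show that the change carries over unaltered, since two single steps are too few for either claim and core and methyl place vary together, the methyl of compound 4 standing ortho to a large group while that of compound 3 stands elsewhere on the ring.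

Open, as far as these compounds go, is how the same methyl placement would read on the core of compound 1, and how the methyl of compound 3 would read on the core of compound 2, pairs that would separate the effect of the core from that of the place. Also open, from the compounds shown here alone, is how the benzoyl ring responds to other groups at these places, such as a methoxy group, an amine or a carboxylic acid.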